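Chain length between aryl ether oxygen and hydroxamate in the lactone series

The source may report more compounds than this note shows. Statements on the series, on what has been measured and on what is new or still open speak of the compounds shown alone.

Measured compounds:
compound 1, `CC(C)CCc1c(OCCCCCCCC(=O)NO)ccc2c1OC(=O)CC2`: > 30000 nM
compound 2, `CC(C)CCc1c(OCCCCCCCC(=O)NO)ccc(CCC(=O)NO)c1O`: 1270 nM
compound 3, `CC(C)CCc1c(OCCCCCC(=O)NO)ccc2c1OC(=O)CC2`: > 30000 nM

In a functional assay on Hep 3B2 cells (Homo sapiens) for antiproliferative activity, read by sulforhodamine B assay, with a stated time of 48 h (on this read-out lower numbers stand for stronger inhibition of growth and higher numbers for weaker inhibition of growth), compound 3 gives only a limit, > 30000 nM. Compound 1 likewise gives only a limit in this assay, > 30000 nM. Compound 2, which carries the shared core in its opened form, gives 1270 nM in this assay. Going by the values given here, the only step within the lactone compounds, a step that the two limits leave unreadable from compound 1 to compound 3, cannot be sized, since both of its ends rest on (the limit of > 30000 nM in this assay, at which 2 of the 3 values shown sit).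

Compound 4, `CC(C)CCc1c(OCCCCCCC(=O)NO)ccc2c1OC(=O)CC2`, is not yet measured. It differs from compound 3 by (hydroxycarbamoyl)methyl in place of hydroxycarbamoyl on a saturated chain carbon, five bonds along the chain from an oxygen on an aromatic ring. This change lies between compound 3 and compound 1 in chain length, and both of those give only a limit in this assay. Among the compounds with values here, the step that the two limits leave unreadable from compound 1 to compound 3 therefore gives no direction to read, and no other measured step bears on the change. Compound 4 is expected to stay at the same limit, with a step that the limit leaves unreadable from compound 3 to compound 4 as the estimated step. The estimate for compound 4 is 40000 nM, with a range from 15000 nM to 120000 nM.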

Compound 4, concentration for 50% growth inhibition: > 30000 nM
Compound 4 ended at the assay's limit; the forecaster's own chance of this, stated with the estimate: 85%; the middle value does not contradict the limit.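

No step among compound 1, compound 3 and compound 4 can be read in this assay, since all three rest on the same limit: the limit of > 30000 nM in this assay, at which 3 of the 4 values shown sit.

Open, as far as these compounds go, is whether any chain length on the shared core in its closed form gives a readable value, and so whether chain length matters at all.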